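This account rests on a few compounds, and the source may have more. Where it says the series, first, only, none or still open, it means among the compounds named here.

The study measured two compounds in an ADME assay on Huh-7 cells (Homo sapiens) for cytotoxicity, read by a luciferase reporter and WST assay, with a stated time of 3 days; a higher number here means that more compound is tolerated, a lower number that less compound is tolerated. Compound 1, `O=C(Nc1ccccc1)c1c(NO)cc(-c2ccc(F)cc2)oc1=O`, gives 10300 nM in this assay. Compound 2, `Cc1cccc(NC(=O)c2c(NO)cc(-c3ccccc3)oc2=O)c1`, gives > 20000 nM in this assay, and this value is a limit of the assay rather than a number. Compound 2 thus stands at the limit of > 20000 nM in this assay, at which 1 of the 2 values shown sits, and how far beyond it the true value lies is not known. Among the compounds with values here, compound 1 and compound 2 differ from each other in more than one place, so no single step between them is set out; their two values show only that one compound gave a number and the other a limit.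

Compound 3, `O=C(NCc1ccccc1)c1c(NO)cc(-c2ccccc2)oc1=O`, has not yet been measured in this assay. It differs from compound 2 in one place: benzyl in place of 3-methylphenyl on an amide-type nitrogen. Within the data shown here, nothing among the measured compounds bears on this change. A step from compound 2 to compound 3 is expected to be small, with no direction beyond the scatter, and the expected step is a number no higher from compound 2 to compound 3 (the limit leaves the size open). Compound 3 is accordingly estimated at 20000 nM in this assay, with a range from 8000 nM to 40000 nM.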

Compound 3, half-maximal cytotoxic concentration: > 20000 nM
Compound 3: a limit, no number (the forecaster's own chance of this, stated with the estimate: 55%); the middle value sits exactly at the limit.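

Compound 2 and compound 3 both give a limit rather than a number in this assay, so no step can be read between them for benzyl in place of 3-methylphenyl on an amide-type nitrogen: the limit of > 20000 nM in this assay, at which 2 of the 3 values shown sit.

The compounds shown leave open how far past that limit the true value of either compound lies, and whether the two differ at all.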